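A few compounds are considered here, and "the series" means these few. Any claim that something is new, unique, unknown or untested is made for them only; others in the source may bear on it.

Working notes, series around the shared core of compound 1 `CCOC(=O)C1=C(C(F)(F)F)NC(=O)NC1c1ccco1`. In an assay on HeLa cells for displacement of a labelled ligand from adenosine receptor A3 (Homo sapiens), with a stated time of 180 min, tested at 10 uM (on this read-out lower numbers stand for less inhibition and higher numbers for more inhibition at the one concentration tested (going by the name of the read-out)), compound 1 gives 2%. Compound 2 `CCCC1=C(C(=O)OCC)C(c2ccco2)NC(=O)N1` gives 19% in this assay. Within the data shown here, the single step measured so far, a number 17 percentage points higher from compound 1 to compound 2 (beyond the scatter), places compound 2 at the highest of the two numbers, with compound 1 the nearest and only other value, beyond the scatter below it.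

The next compound, compound 3 `CCOC(=O)C1=C(c2ccccc2)NC(=O)NC1c1ccco1`, has not yet been measured in this assay. It differs from compound 2 in one place: phenyl in place of propyl on a double-bonded ring carbon. Among the measured compounds shown here, the only measured step that bears on this change is a number 17 percentage points higher from compound 1 to compound 2 (beyond the scatter), which concerns the same double-bonded ring carbon but exchanges trifluoromethyl for propyl, not propyl for phenyl; it shows that this position can move the read-out by a modest amount, and nothing more. For the measured compounds named here, with no step exchanging propyl for phenyl on the shared core, the direction rests on that one modest step alone, and a small rise or a step within the scatter is expected in this assay, a number 6 percentage points higher from compound 2 to compound 3 (within the scatter).

For compound 3 the estimate in this assay is 25%, with a range from 5% to 50%.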

Compound 3, a percentage reported as inhibition, at one concentration (the size of the read-out at that concentration, not a potency): 2%
Beside the measured number, compound 3's estimate is 23 percentage points above it; the measured number lies below the stated range.
By their numbers in this assay, from the lowest: compounds 1 and 3 (each within the scatter of the next); then compound 2.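

Phenyl in place of propyl gives a number 17 percentage points lower from compound 2 to compound 3 (beyond the scatter) in this assay, so a change on this double-bonded ring carbon can lower the number as well as raise it, and a larger group with an aromatic ring does not extend the rise seen with propyl. Phenyl in place of trifluoromethyl gives no change at the digits printed from compound 1 to compound 3 (within the scatter), so these two groups cannot be told apart on this read-out, while compound 2 stands beyond the scatter from both and propyl is the only one of the three groups here that lifts the number. The data at hand offer no measurement that explains why propyl differs from phenyl and trifluoromethyl at this position.

On these data alone, three groups on this carbon give no trend, and it remains open whether a longer chain such as butyl, or an amine or a carboxylic acid, would fall with propyl or with the other two. As far as these compounds go, it also remains open whether the difference between propyl and phenyl holds when the ethoxycarbonyl or furan-2-yl group of the shared core is replaced.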